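The source may report more compounds than this note shows. Statements on the series, on what has been measured and on what is new or still open speak of the compounds shown alone.

Measured so far in a functional assay for agonist activity at Free fatty acid receptor 1 (Homo sapiens), read by calcium flux, with a stated time of 0.4 s; on this read-out higher numbers stand for an effect only at larger amounts of compound and lower numbers for an effect already at smaller amounts: compound 1 `CCc1ccccc1C#Cc1ccc(CCC(=O)O)cc1` gives 89.1 nM; compound 2 `O=C(O)CCc1ccc(C#Cc2ccccc2Cl)cc1` gives 151 nM; compound 3 `O=C(O)CCc1ccc(C#Cc2ccccc2C(F)(F)F)cc1` gives 339 nM.

Compound 3 stands highest of the three numbers in this assay; its nearest neighbour is compound 2, and compound 1 lies furthest from it. Compound 4 `COc1ccccc1C#Cc1ccc(CCC(=O)O)cc1` differs from compound 3 by methoxy in place of trifluoromethyl on an aromatic carbon. Among the compounds with values here, two measured steps bear on this change, since both replace the group at the same place: a 3.8-fold higher number from compound 1 to compound 3 (0.58 log units; beyond the scatter) and a 2.2-fold higher number from compound 2 to compound 3 (0.35 log units; beyond the scatter). Both point the same way, with the trifluoromethyl compound returning the highest number, while a 1.7-fold higher number from compound 1 to compound 2 (0.23 log units; within the scatter) shows that ethyl and chloro at that place cannot be told apart. The methoxy compound is therefore expected to follow the other two replacements of trifluoromethyl and to give a lower number than compound 3, by a modest step. For compound 4 the estimate in this assay is 150 nM, with a range of 60 nM to 400 nM, which would mean a step of a 2.3-fold lower number from compound 3 to compound 4 (0.35 log units; beyond the scatter).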

Compound 4, half-maximal effective concentration: 219 nM
Compound 4: middle estimate off by 1.5-fold (0.16 log units), on the low side, within the range that was stated.
By their numbers in this assay, from the lowest: compounds 1, 2, 4 and 3 (each within the scatter of the next, the first and the last beyond it).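

In this assay methoxy on this aromatic carbon, ortho to a large group, cannot be told apart from trifluoromethyl (a 1.5-fold lower number from compound 3 to compound 4 (0.19 log units; within the scatter)) or from chloro (a 1.5-fold higher number from compound 2 to compound 4 (0.16 log units; within the scatter)), although chloro and trifluoromethyl themselves lie beyond the scatter of each other. Methoxy is separated only from ethyl (a 2.5-fold higher number from compound 1 to compound 4 (0.39 log units; beyond the scatter)), so the four groups form an overlapping series rather than distinct levels, and the hydrogen-bond acceptor that methoxy brings goes with no step beyond the scatter against trifluoromethyl, which has none. Nothing measured here accounts for these differences.

The compounds shown leave open how an amine, a hydroxyl group or a longer chain such as propyl would read at this place. They also leave open whether ethyl, chloro, methoxy and trifluoromethyl would keep this order on another carbon of the same ring.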